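A few compounds are considered here, and "the series" means these few. Any claim that something is new, unique, unknown or untested is made for them only; others in the source may bear on it.

In an ADME assay on HEK293 cells (Homo sapiens) for cytotoxicity, read by resazurin assay, with a stated time of 48 h (a lower number here means that less compound is tolerated, a higher number that more compound is tolerated), compound 3 `O=S(=O)(Nc1ccc(-c2nc3ccccc3o2)cc1)c1ccc(O)cc1` gives > 100000 nM as a limit and not a number. Compound 1 `O=S(=O)(Nc1ccc(-c2nc3ccccc3o2)cc1)c1cccs1` likewise gives > 100000 nM as a limit. Compound 2 `O=S(=O)(Nc1ccc(-c2nc3ccccc3o2)cc1)c1ccccc1O` gives > 100000 nM as a limit too. Compound 4 `O=S(=O)(Nc1ccc(-c2nc3ccccc3o2)cc1)c1ccc(C(F)(F)F)cc1` follows from compound 3 through trifluoromethyl in place of hydroxy on an aromatic carbon with trifluoromethyl in place of hydroxy on an aromatic carbon. The nearest measured steps change the group on the sulfonyl sulfur, and none has a size that can be read: there is a step that the two limits leave unreadable from compound 1 to compound 3 and a step that the two limits leave unreadable from compound 2 to compound 3 as well as a step that the two limits leave unreadable from compound 1 to compound 2 among them. None of them swaps hydroxy for trifluoromethyl, so no step beyond the scatter is expected in this assay here. For compound 4 the expected step is a number no higher from compound 3 to compound 4 (the limit leaves the size open) by this estimate. For compound 4 the estimate is 100000 nM with an expected range from 30000 nM to 300000 nM in this assay as well.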

Compound 4, half-maximal cytotoxic concentration: 94000 nM
Beside the measured number, compound 4's estimate is 1.1-fold (0.03 log units) above it; measured number inside the range.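

In this assay, trifluoromethyl in place of hydroxy on an aromatic carbon para to a large group gives an at least 1.0-fold lower number from compound 3 to compound 4 (0.02 log units; that floor lies within the scatter). Within the data shown here, compound 4 thus supplies the first number at this position, whereas the earlier steps could not be read. The size of the change remains bounded on one side only, and the comparison rests on this: the limit of > 100000 nM in this assay, at which 3 of the 4 values shown sit.

As far as these compounds go, what an amine or a carboxylic acid on this aromatic carbon would give remains open. So does the true value behind the limit for compound 3.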